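Series notes: phenyl for methyl on two cores, cell toxicity

The source may hold more compounds than are shown below. What is called first, only, known or untested is meant among the compounds shown, and "the series" means these compounds.

Measured compounds:
compound 1 `Cc1ccc(NC(=O)CCCn2cc(-c3ccc(C(F)(F)F)cc3)nn2)cc1` gives > 100000 nM
compound 2 `O=C(CCCn1cc(-c2ccc(C(F)(F)F)cc2)nn1)Nc1ccc(-c2ccccc2)cc1` gives > 100000 nM
compound 3 `Cc1ccc(NC(=S)CCCn2cc(-c3ccc(C(F)(F)F)cc3)nn2)cc1` gives > 100000 nM

Each of these three values in a toxicity assay on HEK293 cells (Homo sapiens) for inhibition, read by MTT assay, with a stated time of 72 h (on this read-out higher numbers stand for weaker inhibition and lower numbers for stronger inhibition), is a limit of the assay and not a number. The value of compound 1 is such a limit. The value of compound 2 is such a limit. The value of compound 3 is such a limit. The change from compound 1 to compound 2 is phenyl in place of methyl on an aromatic carbon; its step is a step that the two limits leave unreadable from compound 1 to compound 2, which follows from the limit of > 100000 nM in this assay, at which 3 of the 3 values shown sit. Compound 3 differs from compound 1 in its core, and the difference between the two cores is not broken down here.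

Compound 4 `FC(F)(F)c1ccc(-c2cn(CCCC(=S)Nc3ccc(-c4ccccc4)cc3)nn2)cc1` is not yet measured. Its change from compound 3 is phenyl in place of methyl on an aromatic carbon, the same change as from compound 1 to compound 2, at a place described in the same words. The expected step that the limit leaves unreadable from compound 3 to compound 4 is small. Compound 4 is expected to give 150000 nM, most likely again as a limit, because compound 3 gives > 100000 nM and the same change was unreadable within limits. Compound 4 is estimated between 40000 nM and 500000 nM.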

Compound 4, half-maximal inhibitory concentration: > 100000 nM
Compound 4 was reported as a limit; the forecaster's own chance of this, stated with the estimate: 85%; the middle value does not contradict the limit.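

No new step can be read: the change from compound 3 to compound 4 stays unreadable, as does its counterpart from compound 1 to compound 2, because both values in each pair are limits in this assay: the limit of > 100000 nM in this assay, at which 4 of the 4 values shown sit.

The compounds shown leave open whether phenyl in place of methyl, or the difference between the two cores, has any effect on the read-out in this assay.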